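Swapping one five-membered ring for another

A few compounds are considered here, and "the series" means these few. Any claim that something is new, unique, unknown or untested is made for them only; others in the source may bear on it.

In an ADME assay on the whole organism (serum) for protein binding, with Homo sapiens as the target, using equilibrium dialysis, compound 1 (`O=C(O)c1cn(Cc2ccc(-c3ccccc3)cc2)c2ncccc2c1=O`) reads 99.2% and compound 2 (`Cc1ccn(-c2ccc(Cn3cc(C(=O)O)c(=O)c4cccnc43)cc2)n1`) reads 98.8% and these two values lie within the scatter of each other. Compound 3 (`Cc1cn(-c2ccc(Cn3cc(C(=O)O)c(=O)c4cccnc43)cc2)cn1`) keeps the rest of compound 2 but carries 4-methyl-1H-imidazol-1-yl in place of 3-methyl-1H-pyrazol-1-yl on an aromatic carbon, para to a large group (4-methyl-1H-imidazol-1-yl in place of 3-methyl-1H-pyrazol-1-yl on an aromatic carbon). The two compounds have the same atoms, joined differently. Among the compounds with values here, only one measured step bears on this, an exchange at the same place (a 1.5-fold higher unbound fraction from compound 1 to compound 2 (0.18 log units; within the scatter)) and it stayed within the scatter. With that single step as a guide, the expected change is small, a 1.5-fold higher unbound fraction from compound 2 to compound 3 (0.18 log units; within the scatter) in this assay and so nothing beyond the scatter. Compound 3 is estimated at 98.2% with an expected range from 95.5% to 99.2% for the measurement.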

Compound 3, plasma protein binding: 76.7%
Compound 3: middle estimate off by 13-fold (1.11 log units) (unbound fraction), on the low side, and the stated range ends above it.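

In this assay this position proves far more sensitive than the earlier pair suggested: 4-methyl-1H-imidazol-1-yl in place of 3-methyl-1H-pyrazol-1-yl gives a 19-fold higher unbound fraction from compound 2 to compound 3 (1.29 log units; beyond the scatter) even though the two groups hold the same atoms and differ only in how they are joined. The step from the phenyl group is of similar scale, with a 29-fold higher unbound fraction from compound 1 to compound 3 (1.46 log units; beyond the scatter) at the same place, so 4-methyl-1H-imidazol-1-yl stands apart from both other groups. Nothing available explains this large shift.

On these data alone, it remains open whether the shift comes from the imidazole ring itself or depends on its methyl group, which a plain 1H-imidazol-1-yl group would help to separate. As far as these compounds go, how another ring with nitrogen at this place, such as a 1H-1,2,4-triazol-1-yl or a pyridine ring, would behave also remains unknown.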